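A few compounds are considered here, and "the series" means these few. Any claim that something is new, unique, unknown or untested is made for them only; others in the source may bear on it.

Three compounds in the series carry a shared core and have been measured in a functional assay on DLD-1 cells (Homo sapiens) for cytotoxicity, read by MTT assay, with a stated time of 48 h; on this read-out higher numbers stand for weaker inhibition and lower numbers for stronger inhibition. Compound 1 `CN(C)CCNc1ccnc2cc(OCc3ccc(F)cc3)ccc12` gives 810 nM, compound 2 `CN(C)CCNc1ccnc2cc(OCc3ccccc3)ccc12` gives 2140 nM, and compound 3 `Clc1ccnc2cc(OCc3ccccc3)ccc12` gives 3270 nM. Compound 2 therefore stands second highest of the three numbers, with compound 3 nearest and compound 1 furthest from it. The two measured steps are a 2.6-fold higher number from compound 1 to compound 2 (0.42 log units; beyond the scatter) and a 1.5-fold higher number from compound 2 to compound 3 (0.18 log units; within the scatter).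

Compound 4 `C=CCOc1ccc2c(NCCN(C)C)ccnc2c1` differs from compound 2 by vinyl in place of phenyl on a saturated chain carbon bound to an oxygen on an aromatic ring. Among the measured compounds shown here, no measured step removes the phenyl itself; the closest comparison is the step from compound 1 to compound 2, where only a fluoro on that phenyl was exchanged for hydrogen and the number rose modestly. Removing the whole ring is a larger change, so a rise at least of that order is expected, though its size is uncertain. On that basis compound 4 is expected to give 4500 nM in this assay, within a range of 1500 nM to 14000 nM, which would correspond to an estimated step of a 2.1-fold higher number from compound 2 to compound 4 (0.32 log units; beyond the scatter).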

Compound 4, half-maximal inhibitory concentration: 1530 nM
Estimate against measurement, compound 4: 2.9-fold (0.47 log units) above; low and high end bracket the measured number.
By their numbers in this assay, from the lowest: compounds 1, 4, 2 and 3 (each within the scatter of the next, the first and the last beyond it).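

In this assay, vinyl in place of phenyl on a saturated chain carbon bound to an oxygen on an aromatic ring gives a 1.4-fold lower number from compound 2 to compound 4 (0.15 log units; within the scatter), so at this place, in this pair, losing the aromatic ring of the benzyloxy group and moving to allyloxy leaves the number within the scatter. Vinyl in place of 4-fluorophenyl gives a 1.9-fold higher number from compound 1 to compound 4 (0.28 log units; within the scatter), so the allyloxy compound cannot be told apart from either benzyloxy compound, although those two differ from each other beyond the scatter. No measurement on hand accounts for this result.

The compounds shown leave open whether a propyl or a plain ethyl at this place would stay in the same range, which would test whether the double bond of the vinyl matters. They also leave open how a morpholine in place of the (2-(dimethylamino)ethyl)amino would read alongside the allyloxy group.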